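A few compounds are considered here, and "the series" means these few. Any claim that something is new, unique, unknown or untested is made for them only; others in the source may bear on it.

Three close relatives of one shared core have been measured in an ADME assay on microsomes from liver (Homo sapiens) for metabolic stability, using NADPH, with a stated time of 40 min, tested at 2 uM; a lower number here means that the compound disappears faster, a higher number that the compound lasts longer. Compound 1, `Cc1cccc2c(-c3ccc4ccc(Cl)cc4n3)c[nH]c12`, gives 1.48 h. Compound 2, `Cc1cccc2c(-c3ccc4cccc(F)c4n3)c[nH]c12`, gives 0.983 h. Compound 3, `Cc1cc(F)cc2c(-c3ccc4ccccc4n3)c[nH]c12`, gives 1.1 h. The number for compound 2 is the smallest of the three, yet its gap to compound 3 and its gap to compound 1 both lie within the usual scatter of this assay, so the three compounds cannot be separated on these data.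

Compound 4, `Cc1cccc2c(-c3ccc4cccc(Cl)c4n3)c[nH]c12`, has not yet been measured. It differs from compound 2 in a single place: chloro in place of fluoro on an aromatic carbon. Among the compounds with values here, no pair of measured compounds differs in only that way, so there is no measured step to lean on; the expectation rests only on the three numbers above and on the small size of the change.

Because compound 1 with its chloro gives 1.48 h and compound 2 gives 0.983 h, the step from compound 2 to compound 4 in this assay is expected to be small, a 1.2-fold higher number from compound 2 to compound 4 (0.09 log units; within the scatter), and not beyond the scatter. Compound 4 is therefore estimated at 1.2 h, with a likely range from 0.6 h to 2.4 h.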

Compound 4, half-life: 1.75 h
Compound 4: the middle estimate sits 1.5-fold (0.16 log units) below what was measured; low and high end bracket the measured number.
By their numbers in this assay, from the lowest: compounds 2, 3, 1 and 4 (each within the scatter of the next).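

In this assay, chloro in place of fluoro on an aromatic carbon, ortho to a fused ring and meta to a fused ring, gives a 1.8-fold higher number from compound 2 to compound 4 (0.25 log units; within the scatter). Within the data shown here, this is the first direct reading of this exchange at this position, which the earlier compounds could not give, as each differs from the others in more than one place. At this position, the two halogens cannot be told apart by half-life, and nothing shown accounts for the size of the step.

Going by these compounds, it remains open whether the step would stay this small with a different group at this position, such as an amine, a methoxy group or a carboxylic acid. It is also unknown whether chloro and fluoro would be as hard to separate elsewhere on the shared core.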